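Compound 4: 3-chloropyridin-2-yl replaces phenyl on the amide nitrogen

The source may hold more compounds than are shown below. What is called first, only, known or untested is meant among the compounds shown, and "the series" means these compounds.

Of the compounds shown here, three built on one shared core have been tested in a functional assay on U-87MG ATCC cells for inhibition, with U-87 MG (Homo sapiens) as the target, read by MTT assay, with a stated time of 72 h; on this read-out higher numbers stand for weaker inhibition and lower numbers for stronger inhibition. Compound 1 `Cc1noc(C)c1-c1cnc(N)c(Oc2ccc(C(=O)NC3CCCCC3)cc2)n1` gives 40400 nM. Compound 2 `Cc1noc(C)c1-c1cnc(N)c(Oc2ccc(C(=O)Nc3ccccc3)cc2)n1` gives 26600 nM, and compound 3 `Cn1cc(-c2cnc(N)c(Oc3ccc(C(=O)Nc4ccccc4)cc3)n2)cn1` gives 17700 nM. The step of a 1.5-fold lower number from compound 1 to compound 2 (0.18 log units; within the scatter) and the step of a 1.5-fold lower number from compound 2 to compound 3 (0.18 log units; within the scatter) each stay inside the scatter. Compound 3 therefore has the lowest number of the three, but it cannot be told apart from compound 2; only its gap to compound 1 lies beyond the scatter.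

Compound 4 `Cn1cc(-c2cnc(N)c(Oc3ccc(C(=O)Nc4ncccc4Cl)cc3)n2)cn1` differs from compound 3 in a single place: 3-chloropyridin-2-yl in place of phenyl on an amide-type nitrogen. Just one measured step touches the same amide-type nitrogen, the change from cyclohexyl to phenyl, and that step stayed within the scatter. Within the data shown here, no measured step shows what a 3-chloropyridin-2-yl group does at this position, so the only guide is that the earlier change at this nitrogen moved the number little. A small step, if any, is expected, leaning toward a lower number. Compound 4 is expected to give about 12000 nM in this assay, with a likely range from 4000 nM to 35000 nM. This corresponds to an expected 1.5-fold lower number from compound 3 to compound 4 (0.17 log units; within the scatter).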

Compound 4, half-maximal inhibitory concentration: 37600 nM
The estimate for compound 4 lay 3.1-fold (0.50 log units) below the measured number; the measured number lies above the stated range.
By their numbers in this assay, from the lowest: compounds 3, 2, 4 and 1 (each within the scatter of the next, the first and the last beyond it).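

In this assay, among these compounds, this amide-type nitrogen proves able to move the number: putting 3-chloropyridin-2-yl in place of phenyl gives a 2.1-fold higher number from compound 3 to compound 4 (0.33 log units; beyond the scatter) and so is the first change here at this nitrogen to lie beyond the scatter. The earlier change at the same nitrogen, phenyl in place of cyclohexyl, gave only a 1.5-fold lower number from compound 1 to compound 2 (0.18 log units; within the scatter) and could not show this. The new group also moves the number toward weaker inhibition, so adding a ring nitrogen and a chlorine to this aromatic ring does not help in this setting, although no measurement at hand explains the step.

The new group differs from phenyl in two ways at once, so a pyridinyl group without the chlorine and a chlorophenyl group would be needed to show which part goes with the higher number. Also open, going by these compounds, are how a carboxylic acid or an amine carried on this ring would behave, and whether the same swap gives a similar step when 3,5-dimethyl-1,2-oxazol-4-yl sits on the shared core.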